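Chain variation on the aromatic oxygen of the shared core

The source may report more compounds than this note shows. Statements on the series, on what has been measured and on what is new or still open speak of the compounds shown alone.

Compound 1 `CCOc1ccc(C(O)C2OC(=O)c3c(OC)cc(OC)cc32)cc1` reaches only the limit of a functional assay on RAW264.7 cells (Mus musculus) for inhibition, read by Griess assay, with stated times of 1 h and 24 h (a lower number here means a stronger inhibitor, a higher number a weaker inhibitor), returning > 10000 nM, which is a limit of the assay rather than a number (the limit of > 10000 nM in this assay, at which 1 of the 3 values shown sits). Compound 2 `CCCOc1ccc(C(O)C2OC(=O)c3c(OC)cc(OC)cc32)cc1` gives 9260 nM in this assay. Compound 3 `COc1cc(OC)c2c(c1)C(C(O)c1ccc(OCc3ccc(Cl)cc3)cc1)OC2=O` gives 4320 nM in this assay. Compound 4 `COc1cc(OC)c2c(c1)C(C(O)c1ccc(OCc3ccc(OC(F)(F)F)cc3)cc1)OC2=O` differs from compound 1 as follows: 4-(trifluoromethoxy)phenyl in place of methyl on a saturated chain carbon bound to an oxygen on an aromatic ring. The measured steps that touch the same place are an at least 2.3-fold lower number from compound 1 to compound 3 (0.36 log units; beyond the scatter) and a 2.1-fold lower number from compound 2 to compound 3 (0.33 log units; beyond the scatter), whereas an at least 1.0-fold lower number from compound 1 to compound 2 (0.03 log units; that floor lies within the scatter). A change of comparable kind is expected for compound 4, with the step estimated as an at least 2.2-fold lower number from compound 1 to compound 4 (0.34 log units; beyond the scatter). Compound 4 is therefore expected to give about 4500 nM in this assay, in the range 1800 nM to 11000 nM.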

Compound 4, half-maximal inhibitory concentration: 8140 nM
The estimate for compound 4 lay 1.8-fold (0.26 log units) below the measured number, and the stated range covers the measured number.
By their numbers in this assay, from the lowest: compounds 3, 4 and 2 (each within the scatter of the next, the first and the last beyond it). At a limit, above all of these: compound 1.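

Within this assay, trifluoromethoxy in place of chloro on the aromatic carbon gives a 1.9-fold higher number from compound 3 to compound 4 (0.28 log units; within the scatter), so compounds 3 and 4 are not separated at this position. The modest step from ethyl to 4-chlorophenyl does not carry over to 4-(trifluoromethoxy)phenyl, which gives a 1.1-fold lower number from compound 2 to compound 4 (0.06 log units; within the scatter). Against compound 1 the step is only a floor, an at least 1.2-fold lower number from compound 1 to compound 4 (0.08 log units; that floor lies within the scatter), and it rests on a limit rather than a number: the limit of > 10000 nM in this assay, at which 1 of the 4 values shown sits.

Going by these compounds, whether an amine, a carboxylic acid or a longer chain on this saturated chain carbon would move the number beyond the scatter remains open.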